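The source may report more compounds than this note shows. Statements on the series, on what has been measured and on what is new or still open speak of the compounds shown alone.

Measured compounds:
- compound 1, `O=C(O)CCc1ccc(OCc2coc(-c3cccc(Cl)c3)n2)cc1`: in a functional assay on CHO cells for agonist activity at Free fatty acid receptor 1 (Homo sapiens), read by FLIPR and calcium flux, in the presence of a further agent that is not named here (a lower number here means that less compound is needed, a higher number that more compound is needed for the effect), compound 1 gives 160 nM
- compound 2, `Cc1ccc(-c2noc(COc3ccc(CCC(=O)O)cc3)n2)cc1`: in this assay compound 2 gives 300 nM
- compound 3, `CC(Oc1ccc(CCC(=O)O)cc1)c1nc(-c2cccs2)no1`: in this assay compound 3 gives 4000 nM

All three share a propanoic acid chain on a phenyl ring joined through an ether to a five-membered heteroaromatic ring carrying a further aryl group. Compound 2 has the second highest number of the three. Its nearest neighbour is compound 1, whose value lies within the scatter of compound 2, so the two cannot be told apart. Compound 3 lies furthest away, with a number beyond the scatter above compound 2.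

Compound 4, `O=C(O)CCc1ccc(OCc2nc(-c3ccccc3)no2)cc1`, is the compound still to be measured. It differs from compound 2 in a single place:

hydrogen in place of methyl on an aromatic carbon

Going by the values given here, no pair of measured compounds differs in just this way, so the size of the step is not known from the data. Removing one carbon from the outer aryl ring is a small change, and in this assay the step is expected to be modest, if anything toward a somewhat higher number, likely within or only just beyond the scatter. Compound 4 is therefore estimated at 500 nM, with a range from 200 nM to 1500 nM, which corresponds to an expected step of a 1.7-fold higher number from compound 2 to compound 4 (0.22 log units; within the scatter).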

Compound 4, half-maximal effective concentration: 1130 nM
The estimate for compound 4 lay 2.3-fold (0.35 log units) below the measured number; low and high end bracket the measured number.
By their numbers in this assay, from the lowest: compounds 1 and 2 (each within the scatter of the next); then compound 4; then compound 3.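

In this assay going from 4-methylphenyl to phenyl gives a 3.8-fold higher number from compound 2 to compound 4 (0.58 log units; beyond the scatter) and so shows that a single methyl on the outer ring can matter. Going by these compounds alone, this is the only step here between compounds that differ in one place, and the loss of one carbon moves the number beyond the scatter, so what sits at this position, para to a large group, is not a matter of indifference. No measurement offered here explains why the methyl counts in this way. The compounds shown leave open whether an ethyl, a methoxy group or a fluorine in the same place would match the methyl, better it or fall short. They also leave open whether removing the methyl would cost the same on a different core, such as that of compound 1.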